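The source may hold more compounds than are shown below. What is called first, only, known or untested is meant among the compounds shown, and "the series" means these compounds.

Measured so far:
- compound 1, `COc1cc(-n2ncnc2-c2cccc([N+](=O)[O-])c2)cc(OC)c1OC`: in a functional assay on A549 cells (Homo sapiens) for antiproliferative activity, read by MTT assay, with a stated time of 72 h (on this read-out lower numbers stand for stronger inhibition and higher numbers for weaker inhibition), only a limit is reported, > 10000 nM
- compound 2, `COc1cc(-n2ncnc2-c2ccc(OC(C)C)cc2)cc(OC)c1OC`: in this assay only a limit is reported, > 10000 nM
- compound 3, `COc1cc(-c2ncnn2-c2ccccc2)cc(OC)c1OC`: in this assay only a limit is reported, > 10000 nM

None of the three compounds gives a number in this assay; every value shown is a limit of the assay (the limit of > 10000 nM in this assay, at which 3 of the 3 values shown sit). Compound 2 therefore stands nowhere in particular among the three: its value is a limit, the same limit as the other two, and no order among them can be read. Going by the values given here, no pair of measured compounds differs in one place, so no measured step is available.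

Compound 4, `COc1cc(-n2ncnc2-c2ccc(C)cc2)cc(OC)c1OC`, is not yet measured. It differs from compound 2 in one place: methyl in place of isopropoxy on an aromatic carbon. With every shown compound at the limit and nothing to indicate that a small change on that ring moves the read-out, the step is expected to be none beyond the scatter, in either direction. Compound 4 is expected to give 15000 nM, with a range from 5000 nM to 50000 nM, most probably reported again as a limit only. The step this estimate means, a step that the limit leaves unreadable from compound 2 to compound 4, is expected to be none beyond the scatter.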

Compound 4, half-maximal inhibitory concentration: 1100 nM
Beside the measured number, compound 4's estimate is 14-fold (1.13 log units) above it; the whole stated range lies above it.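

This position on the aromatic ring, para to a large group, is not silent in this assay: methyl in place of isopropoxy gives an at least 9.0-fold lower number from compound 2 to compound 4 (0.95 log units; beyond the scatter), which makes compound 4 the only one of the four compounds shown with a real number. The earlier compounds shown here offered no measured step, so the shared core could have been read as inactive whatever sat on that ring; this pair rules that reading out for at least one substituent. The step is a lower bound and its true size cannot be read, because compound 2 sits at a limit: the limit of > 10000 nM in this assay, at which 3 of the 4 values shown sit.

As far as these compounds go, the pair cannot separate the loss of the ether oxygen from the shortening of the group, and it remains open whether ethyl, methoxy, a chlorine atom or a dimethylamino group at this place would keep the number of compound 4. From the compounds shown here alone, it is equally open whether a methyl group elsewhere on this ring would have the same effect, and whether the step carries over to other cell lines.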